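This account rests on a few compounds, and the source may have more. Where it says the series, first, only, none or still open, it means among the compounds named here.

Working notes on cytotoxicity in the series. In an ADME assay on Vero cells (Chlorocebus sabaeus) for cytotoxicity, with a stated time of 72 h (on this read-out lower numbers stand for higher toxicity in this test and higher numbers for lower toxicity in this test), compound 1 `O=C(/C=C/c1ccc(Cl)cc1)c1ccc(N2CCCCC2)cc1` gives 235 ug/mL, compound 2 `O=C(c1ccc(NCc2ccco2)cc1)C1CC1c1ccc(Cl)cc1` gives 256 ug/mL, and compound 3 `CCCCCCCNc1ccc(C(=O)C2CC2c2ccc(OC)c(OC)c2)cc1` gives 273 ug/mL. Compound 2 falls in the middle of these three numbers, and its gaps to compound 1 and to compound 3 are both inside the scatter, so the three read as one level. For the measured compounds named here, no pair of measured compounds differs in a single place, so no computed step is available. Compound 4 `O=C(c1ccc(NCCn2cncn2)cc1)C1CC1c1ccc(Cl)cc1` differs from compound 2 by (1H-1,2,4-triazol-1-yl)methyl in place of furan-2-yl on a saturated chain carbon bound to a nitrogen on an aromatic ring. With the measured numbers all at one level, no step beyond the scatter is expected here; the estimated step of a 1.0-fold lower number from compound 2 to compound 4 (0.01 log units; within the scatter) is flat. Compound 4 is expected at 250 ug/mL, in the range 130 ug/mL to 480 ug/mL.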

Compound 4, half-maximal cytotoxic concentration: 39.9 ug/mL
Beside the measured number, compound 4's estimate is 6.3-fold (0.80 log units) above it, and the stated range ends above it.
By their numbers in this assay, from the lowest: compound 4; then compounds 1, 2 and 3 (each within the scatter of the next).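

In this assay, for the compounds shown here, the place on a saturated chain carbon bound to a nitrogen on an aromatic ring proves responsive: (1H-1,2,4-triazol-1-yl)methyl in place of furan-2-yl gives a 6.4-fold lower number from compound 2 to compound 4 (0.81 log units; beyond the scatter) and is the only step beyond the scatter. The earlier compounds shown here, which read as one level, gave no sign of this sensitivity. No evidence at hand bears on this result.

The change alters both the ring and the chain length, so the step cannot be assigned to either one. A 2-(furan-2-yl)ethyl group at this place would separate the two.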